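Pyrrolidin-1-yl for methylsulfanyl: one change on two cores

This account rests on a few compounds, and the source may have more. Where it says the series, first, only, none or still open, it means among the compounds named here.

Measured compounds:
compound 1 `CSc1nc(Cl)c(C(=O)c2ccccc2)s1` — in a functional assay on SK-MEL-28 cells (Homo sapiens) for cytotoxicity, read by MTT assay, with a stated time of 72 h (on this read-out higher numbers stand for weaker inhibition and lower numbers for stronger inhibition), compound 1 gives > 100000 nM, which is a limit of the assay.
compound 2 `O=C(c1ccccc1)c1sc(N2CCCC2)nc1Cl` — in this assay compound 2 gives 98000 nM.
compound 3 `COC(=O)c1sc2nc(SC)sc2c1C` — in this assay compound 3 gives > 100000 nM, again a limit of the assay.

The change from compound 1 to compound 2 is pyrrolidin-1-yl in place of methylsulfanyl on an aromatic carbon. Within the data shown here, its size in this assay is an at least 1.0-fold lower number from compound 1 to compound 2 (0.00 log units; that floor lies within the scatter); the step sits on a floor because of the limit of > 100000 nM in this assay, at which 2 of the 3 values shown sit, so it tells only that compound 2 is not weaker than the limit.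

Compound 4 `COC(=O)c1sc2nc(N3CCCC3)sc2c1C` is not yet measured. It arises from compound 3 by pyrrolidin-1-yl in place of methylsulfanyl on an aromatic carbon. This is the same kind of change as that from compound 1 to compound 2, not the same: in compound 4 the place is part of a fused or bridged system of two rings, whereas in compound 2 it is two ring bonds from the ring atom that bears a chloro group and two ring bonds from the ring atom that bears a group of 8 heavy atoms. The difference between the two cores is not broken down here.

In this assay compound 4 is expected to move by about a number no higher from compound 3 to compound 4 (the limit leaves the size open), resting on the flat step from compound 1 to compound 2, an at least 1.0-fold lower number from compound 1 to compound 2 (0.00 log units; that floor lies within the scatter), and on compound 3 sitting at > 100000 nM. Compound 4 is estimated at 100000 nM, between 40000 nM and 300000 nM, most likely reported only as a limit.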

Compound 4, half-maximal inhibitory concentration: > 100000 nM
Compound 4 was reported as a limit; the forecaster's own chance of this, stated with the estimate: 70%; the middle value sits exactly at the limit.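

In this assay compound 3 gives > 100000 nM, a limit of the assay. Among these compounds, compound 4 gives > 100000 nM, also a limit, so no step from compound 3 to compound 4 can be read. The compounds shown leave open how far the true values of compound 3 and compound 4 lie from that limit, and whether pyrrolidin-1-yl in place of methylsulfanyl changes anything on this core.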